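The source may report more compounds than this note shows. Statements on the series, on what has been measured and on what is new or still open speak of the compounds shown alone.

Of the compounds shown here, three have so far been tested in an ADME assay on Huh-7 cells (Homo sapiens) for cytotoxicity; on this read-out lower numbers stand for higher toxicity in this test and higher numbers for lower toxicity in this test. Compound 1 `CN1CCN(CCCNCc2cn(-c3ccc(C(F)(F)F)cc3)nc2-c2ccc(C(F)(F)F)cc2)CC1` gives 2000 nM. Compound 2 `CN1CCN(CCNCc2cn(-c3ccc([N+](=O)[O-])cc3)nc2-c2ccc(Cl)cc2)CC1` gives 5000 nM, and compound 3 `CN1CCN(CCCNCc2cn(-c3ccc([N+](=O)[O-])cc3)nc2-c2ccc(C(F)(F)F)cc2)CC1` gives 4900 nM. The numbers for compound 2 and compound 3 fall within the scatter of each other, and the difference between their two cores is not broken down here.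

Between compound 3 and compound 1 a single change was made: trifluoromethyl in place of nitro on an aromatic carbon That change produced a 2.5-fold lower number from compound 3 to compound 1 (0.39 log units; beyond the scatter).

Compound 4 `CN1CCN(CCNCc2cn(-c3ccc(C(F)(F)F)cc3)nc2-c2ccc(Cl)cc2)CC1` has not yet been measured in this assay. It differs from compound 2 in one spot: trifluoromethyl in place of nitro on an aromatic carbon The surroundings of the spot read word for word as they do for the earlier pair, so this is the same change, made on a different core, and it occurs twice among the compounds shown.

Compound 4 is expected to show a step of a 2.5-fold lower number from compound 2 to compound 4 (0.40 log units; beyond the scatter) in this assay. For the measured compounds named here, that expectation rests only on the one earlier example, compound 3 to compound 1, where the step was a 2.5-fold lower number from compound 3 to compound 1 (0.39 log units; beyond the scatter); whether the second core answers in the same way is exactly what is not yet known. With that reservation, compound 4 is estimated at 2000 nM, with a likely span from 1000 nM to 4500 nM.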

Compound 4, half-maximal cytotoxic concentration: 3000 nM
Beside the measured number, compound 4's estimate is 1.5-fold (0.18 log units) below it; the range from low to high includes it.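

In this assay, putting trifluoromethyl in place of nitro on the core of compound 2 gives a 1.7-fold lower number from compound 2 to compound 4 (0.22 log units; within the scatter). On its own, this step is no larger than the usual differences between repeated measurements, yet set beside the earlier example it gives no sign that the two cores respond differently: the same change on two cores in this assay, a 2.5-fold lower number (0.39 log units; beyond the scatter) from compound 3 to compound 1 and a 1.7-fold lower number (0.22 log units; within the scatter) from compound 2 to compound 4, 1.5-fold (0.17 log units) apart, within the scatter of two such steps. The data are therefore compatible with the change carrying over from one core to the other, but two pairs cannot establish a fixed step size, and they say nothing about why the number shifts or how the change would behave on any other core.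

The compounds shown leave open whether another group in place of nitro on the same aromatic carbon, such as a nitrile, an amine or a carboxylic acid, would give a step of similar size. Also open, as far as these compounds go, is which of the differences between the two cores, if any, affects the size of the step, and whether it would hold on a core with a longer chain leading to the piperazine-bearing end of the molecule.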